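The compounds below may be only part of what the source reports. "The series", "measured", "known", "first", "only" and "open" are said of these compounds alone.

For the measured compounds named here, only two compounds have been tested so far in a functional assay on HepG2 cells (Homo sapiens) for antiproliferative activity, read by MTT assay, with a stated time of 24 h (on this read-out higher numbers stand for weaker inhibition and lower numbers for stronger inhibition), and they differ at one place on the same scaffold. Compound 1 (`O=[N+]([O-])c1ccc(S(=O)(=O)n2c(-c3cn(-c4ccccc4)nc3-c3ccc(C(F)(F)F)cc3)nc3ccccc32)cc1`), which carries nitro there, gives 1070 nM as its value. Compound 2 (`O=S(=O)(c1ccc(F)cc1)n1c(-c2cn(-c3ccccc3)nc2-c2ccc(C(F)(F)F)cc2)nc2ccccc21`), which carries fluoro instead, gives 2730 nM as its value, the higher of the two numbers and so the weaker inhibition.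

The next compound, compound 3 (`O=S(=O)(c1ccc(Cl)cc1)n1c(-c2cn(-c3ccccc3)nc2-c2ccc(C(F)(F)F)cc2)nc2ccccc21`), changes this same place again: chloro in place of fluoro on an aromatic carbon means chloro in place of fluoro on an aromatic carbon, turning the 4-fluorophenyl into a 4-chlorophenyl. Going by the values given here, one measured step bears on this swap, namely a 2.6-fold higher number from compound 1 to compound 2 (0.41 log units; beyond the scatter) as nitro gave way to fluoro, a modest step but beyond the usual scatter. Among the compounds with values here, it shows that this place can move the number, yet no chloro compound has been measured, so the direction is a cautious guess. Chloro is expected to land between the two measured compounds, closer to compound 2. The expected change is a 1.4-fold lower number from compound 2 to compound 3 (0.14 log units; within the scatter) and it may not clear the scatter. Compound 3 is estimated at 2000 nM within a range of 900 nM to 4200 nM.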

Compound 3, half-maximal inhibitory concentration: 3930 nM
Beside the measured number, compound 3's estimate is 2.0-fold (0.29 log units) below it, within the range that was stated.
By their numbers in this assay, from the lowest: compound 1; then compounds 2 and 3 (each within the scatter of the next).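

In this assay, putting chloro in place of fluoro on this ring gives a 1.4-fold higher number from compound 2 to compound 3 (0.16 log units; within the scatter), so the two groups cannot be told apart at this position, and the small gap between compound 2 and compound 3 should not be read as a real trend. The nitro group now stands apart from both, since the change to chloro gives a 3.7-fold higher number from compound 1 to compound 3 (0.57 log units; beyond the scatter), which, together with the earlier step to fluoro, makes compound 1 the strongest inhibitor of the three, though only by a modest margin. This suggests that, among these three groups, the choice of nitro matters at this position and the choice between fluoro and chloro does not, but no measurement at hand offers a reason for that difference.

Still open, from the compounds shown here alone, is whether nitro is unusual here or whether a nitrile, a methoxy group or an amine in the same place would match or pass it. Also open, going by these compounds, is how the number responds to changes elsewhere on the shared core, such as replacing the trifluoromethyl group.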